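The compounds below may be only part of what the source reports. "The series", "measured", "known", "first", "only" and "open" are said of these compounds alone.

Measured in a functional assay on HepG2 cells (Homo sapiens) for antiproliferative activity, read by MTT assay, with a stated time of 48 h; a higher number here means a weaker inhibitor, a lower number a stronger inhibitor:
- Compound 1 `COc1ccc(-c2c(Nc3ccc(C)cc3)c3ccccc3oc2=O)cc1`: 59400 nM
- Compound 2 `COc1ccc(-c2c(Nc3ccc(F)cc3)c3ccc(OC)cc3oc2=O)cc1`: > 100000 nM
- Compound 3 `COc1ccc(-c2c(Nc3ccc(C)c(O)c3)c3ccc(OC)cc3oc2=O)cc1`: 22500 nM

The value for compound 2 is a limit of the assay, not a number. Of the two real numbers, compound 3 has the lower, and the gap to compound 1 lies beyond the scatter.

Compound 4 `COc1ccc(-c2c(Nc3ccc(C)cc3)c3ccc(OC)cc3oc2=O)cc1` differs from compound 3 by one change: hydrogen in place of hydroxy on an aromatic carbon. Hydrogen takes the place of hydroxy on an aromatic carbon, so 3-hydroxy-4-methylphenyl becomes 4-methylphenyl.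

Among the compounds with values here, only one measured step bears on this: an at least 4.4-fold lower number from compound 2 to compound 3 (0.64 log units; beyond the scatter). That step swaps a whole group and starts from a limit, so it is only a partial guide. Compound 1 carries the same 4-methylphenyl group on its own core and gives 59400 nM. Losing the hydroxy is therefore expected to raise the number in this assay by a modest step.

The expected change is a 2.4-fold higher number from compound 3 to compound 4 (0.39 log units; beyond the scatter). The estimate for compound 4 is 55000 nM, with an expected range from 22000 nM to 130000 nM.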

Compound 4, half-maximal inhibitory concentration: 74400 nM
Compound 4: the middle estimate sits 1.4-fold (0.13 log units) below what was measured; measured number inside the range.
By their numbers in this assay, from the lowest: compound 3; then compounds 1 and 4 (each within the scatter of the next). At a limit, above all of these: compound 2.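

In this assay, the hydroxy on the aromatic carbon ortho to a methyl group now has a step of its own, with nothing else changing: a 3.3-fold higher number from compound 3 to compound 4 (0.52 log units; beyond the scatter). The earlier step swapped a whole group and started from a limit, whereas this one ties the difference to the hydroxy alone. With 4-methylphenyl on the nitrogen, methoxy in place of hydrogen on an aromatic carbon shows no difference that can be told from the scatter: a 1.3-fold higher number from compound 1 to compound 4 (0.10 log units; within the scatter). The value for compound 2 is a limit of the assay and not a number: the limit of > 100000 nM in this assay, at which 1 of the 4 values shown sits. Methyl in place of fluoro on an aromatic carbon therefore gives only a floor: an at least 1.3-fold lower number from compound 2 to compound 4 (0.12 log units; that floor lies within the scatter). That floor cannot be told from the scatter.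

On these data alone, it remains open whether an amine or a carboxylic acid on that same carbon would keep the lower number that the hydroxy gives. As far as these compounds go, it is also open whether the hydroxy would have the same effect without the neighbouring methyl group.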